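The compounds below may be only part of what the source reports. "The series", "measured", "known", "first", "only" and "open" are said of these compounds alone.

Going by the values given here, compound 1, `N#CCC(=O)OCCc1c(-c2ccccc2Cl)c2cc(Cl)ccc2[nH]c1=O`, is the weaker of the two compounds measured so far in an ADME assay on HepG2 2.2.15 cells (Homo sapiens) for cytotoxicity (a lower number here means that less compound is tolerated, a higher number that more compound is tolerated), where compound 1 gives 100000 nM; compound 2, `O=C(CN1C(=O)c2ccccc2C1=O)OCCc1c(-c2ccccc2Cl)c2cc(Cl)ccc2[nH]c1=O`, gives 960000 nM in this assay. Among the compounds with values here, the one measured step, a 9.6-fold higher number from compound 1 to compound 2 (0.98 log units; beyond the scatter), shows that enlarging the group on the saturated chain carbon bound to the carbonyl carbon went with a higher tolerated concentration. Compound 3, `O=C(/C=C/c1ccc(C(F)(F)F)cc1)OCCc1c(-c2ccccc2Cl)c2cc(Cl)ccc2[nH]c1=O`, is reached from compound 1 by a different enlargement at a neighbouring position: 2-(4-(trifluoromethyl)phenyl)ethenyl in place of cyanomethyl on a carbonyl carbon. Within the data shown here, because the step of a 9.6-fold higher number from compound 1 to compound 2 (0.98 log units; beyond the scatter) is the only guide, and the group entering compound 3 is of another kind, a smaller rise or no change beyond the scatter is expected here, written as a 1.6-fold higher number from compound 1 to compound 3 (0.20 log units; within the scatter). Compound 3 is therefore estimated to give 160000 nM in this assay, with a range from 40000 nM to 640000 nM.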

Compound 3, half-maximal cytotoxic concentration: > 1400000 nM
Compound 3 gave a limit, no number (the forecaster's own chance of this, stated with the estimate: 15%); middle value at least 8.7-fold (0.94 log units) away from the limit.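

For compound 3, the result in this assay is a limit of the assay and not a number: the limit of > 1400000 nM in this assay, at which 1 of the 3 values shown sits.

The step of an at least 14-fold higher number from compound 1 to compound 3 (1.14 log units; beyond the scatter) shows that a second, quite different large group on this carbonyl carbon also goes with a higher number, this time a group with carbon and fluorine but no nitrogen or oxygen. The step of an at least 1.4-fold higher number from compound 2 to compound 3 (0.16 log units; that floor lies within the scatter) has a floor within the scatter, so these two large groups cannot be put in order here.

In both steps from compound 1, the nitrile leaves and a larger group with a ring enters, so the compounds shown do not separate these two changes. A plain methyl group or a short alkyl chain in place of cyanomethyl remains an open case, as does an amine.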